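This account rests on a few compounds, and the source may have more. Where it says the series, first, only, none or still open, it means among the compounds named here.

Measured in a functional assay on CCRF-CEM cells (Homo sapiens) for antiproliferative activity, with a stated time of 72 h; on this read-out higher numbers stand for weaker inhibition and lower numbers for stronger inhibition:

- Compound 1 `OC[C@H]1O[C@@H](n2cnc3c(NCc4cccc(Br)c4)ncnc32)[C@H](O)[C@@H]1O`: 5000 nM
- Compound 2 `COc1cccc(CNc2ncnc3c2ncn3[C@@H]2O[C@H](CO)[C@@H](O)[C@H]2O)c1`: 7600 nM
- Compound 3 `COc1cccc(CNc2ncnc3c2ncn3[C@@H]2O[C@H](CO)[C@@H](O)[C@H]2O)c1OC`: > 166000 nM

Compound 3 has no true number, only a limit: it sits at the limit of > 166000 nM in this assay, at which 1 of the 3 values shown sits. Compound 4 `OC[C@H]1O[C@@H](n2cnc3c(NCc4ccc(F)cc4F)ncnc32)[C@H](O)[C@@H]1O` carries 2,4-difluorophenyl in place of 2,3-dimethoxyphenyl on a saturated chain carbon bound to a nitrogen on an aromatic ring.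

Going by the values given here, three measured steps bear on this change. Methoxy in place of bromo made little difference, a 1.5-fold higher number from compound 1 to compound 2 (0.18 log units; within the scatter). Adding a second methoxy in place of hydrogen was a large step, an at least 21-fold higher number from compound 2 to compound 3 (1.33 log units; beyond the scatter), and the direct comparison with the bromo compound was also large, an at least 33-fold higher number from compound 1 to compound 3 (1.52 log units; beyond the scatter). Both large steps end at compound 3, and compound 4 has no methoxy at all, so it should return towards compound 1 and compound 2. Fluorine is untested in this set, which leaves the expectation loose.

In this assay a large fall in the number is expected, an estimated at least 20-fold lower number from compound 3 to compound 4 (1.31 log units; beyond the scatter). The expected value for compound 4 is 8000 nM, with an estimated range of 1500 nM to 50000 nM.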

Compound 4, half-maximal inhibitory concentration: 7100 nM
Estimate against measurement, compound 4: 1.1-fold (0.05 log units) above; measured number inside the range.
By their numbers in this assay, from the lowest: compounds 1, 4 and 2 (each within the scatter of the next). At a limit, above all of these: compound 3.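

In this assay, 2,4-difluorophenyl on the saturated chain carbon bound to a nitrogen on an aromatic ring gives an at least 23-fold lower number from compound 3 to compound 4 (1.36 log units; beyond the scatter), while the comparisons with the other two compounds stay small, with a 1.1-fold lower number from compound 2 to compound 4 (0.03 log units; within the scatter) and a 1.4-fold higher number from compound 1 to compound 4 (0.15 log units; within the scatter). Three different groups at this place, 3-bromophenyl, 3-methoxyphenyl and 2,4-difluorophenyl, therefore give values within the scatter of one another, and among the compounds shown only 2,3-dimethoxyphenyl stands apart. As far as these compounds go, the true size of the large step stays unknown, since compound 3 carries only a limit: the limit of > 166000 nM in this assay, at which 1 of the 4 values shown sits.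

The compounds shown do not separate the two fluorines of compound 4, so what either one alone would give remains unknown. They also leave open how an amine or a carboxylic acid on the aromatic ring would fare at this place.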